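The source may hold more compounds than are shown below. What is called first, only, known or untested is meant among the compounds shown, and "the series" means these compounds.

Three compounds were measured in a functional assay on 786-0 cells (Homo sapiens) for cytotoxicity, read by sulforhodamine B assay, with a stated time of 48 h, tested at 0.001 uM; a higher number here means a weaker effect of the compound at the concentration tested, a lower number a stronger effect:

- compound 1, `COc1cc(C)cc(-c2c(-c3ccnc(-c4ccc(C(C)=O)cc4)c3)cnn2CC#N)c1`, gives 102%
- compound 2, `COc1cc(C)cc(-c2nn(CC#N)cc2-c2ccc(-c3cccc(C(C)=O)c3)nc2)c1`, gives 97%
- compound 3, `Cc1cc(O)cc(-c2nn(CC#N)cc2-c2ccnc(-c3ccc(Oc4ccccc4)cc3)c2)c1`, gives 98%

All three numbers sit close to full activity, meaning that at this low concentration none of the compounds does much to the cells. Compound 3 differs from compound 2 by an amount within the usual scatter, and its gap to compound 1 is also within the scatter, so nothing separates the three on these numbers.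

Compound 4, `Cc1cc(O)cc(-c2nn(CC#N)cc2-c2ccnc(-c3ccc(N(C)C)cc3)c2)c1`, is not yet measured. It differs from compound 3 in one place: dimethylamino in place of phenoxy on an aromatic carbon. Since the change is a swap of one group for another on an aromatic carbon, and since the three measured compounds with quite different groups at comparable places all read the same, no step beyond the scatter is expected. The step from compound 3 to compound 4 in this assay is expected to be no change at the digits printed from compound 3 to compound 4 (within the scatter), that is, nothing beyond the scatter. Compound 4 is therefore estimated at 98%, with a range from 88% to 108%.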

Compound 4, a percentage reported as activity, at one concentration (the size of the read-out at that concentration, not a potency): 102%
Compound 4: the middle estimate sits 4 percentage points below what was measured, and the stated range covers the measured number.
By their numbers in this assay, from the lowest: compounds 2, 3, 1 and 4 (each within the scatter of the next).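

In this assay, replacing phenoxy with dimethylamino gives a number 4 percentage points higher from compound 3 to compound 4 (within the scatter). For the compounds shown here, this is the first pair that differs in only one place, so it gives the first direct reading of this position, on an aromatic carbon para to a large group: a group with 7 heavy atoms and a six-membered aromatic ring can give way to one with 3 heavy atoms and no ring, with no step beyond the scatter at this concentration. No measurement here offers an explanation for this result.

From the compounds shown here alone, a carboxylic acid or a primary amine at the same place remains open. Also open, going by these compounds, is whether phenoxy and dimethylamino would separate at a higher concentration, where the cells might respond more clearly.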